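Adding Chlorine to Compound 2

A few compounds are considered here, and "the series" means these few. Any claim that something is new, unique, unknown or untested is made for them only; others in the source may bear on it.

Compound 2, `COc1cc2c(Oc3ccc(NC(=O)c4cn(-c5ccccc5)nn4)cc3F)ccnc2cc1OCCCN1CCC(C)CC1`, was tested in a functional assay on MKN-45 cells (Homo sapiens) for cytotoxicity, read by MTT assay, with a stated time of 72 h (on this read-out lower numbers stand for stronger inhibition and higher numbers for weaker inhibition), and gives 90 nM. Within the data shown here, the only other measured compound, compound 1, `COc1cc2c(Oc3ccc(NC(=O)c4cn(-c5ccccc5Cl)nn4)cc3F)ccnc2cc1OCCCN1CCCC1`, gives 70 nM, a gap that lies within the usual scatter, so the two read as alike. Compound 3, `COc1cc2c(Oc3ccc(NC(=O)c4cn(-c5ccccc5Cl)nn4)cc3F)ccnc2cc1OCCCN1CCC(C)CC1`, has not yet been measured. It differs from compound 2 by chloro in place of hydrogen on an aromatic carbon. Compound 1 already carries this chloro group and gives 70 nM, close to compound 2, so no step beyond the scatter is expected. Compound 3 is estimated to give 75 nM, with a range of 35 nM to 160 nM. The expected step is a 1.2-fold lower number from compound 2 to compound 3 (0.08 log units; within the scatter).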

Compound 3, half-maximal inhibitory concentration: 240 nM
For compound 3 the middle estimate is 3.2-fold (0.51 log units) below the measured one; the whole stated range lies below it.
By their numbers in this assay, from the lowest: compounds 1 and 2 (each within the scatter of the next); then compound 3.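

In this assay, chloro in place of hydrogen on this aromatic carbon, ortho to a large group, is not a neutral change: it gives a 2.7-fold higher number from compound 2 to compound 3 (0.43 log units; beyond the scatter). With the chloro in place, the group on the chain also counts, as 4-methylpiperidin-1-yl in place of pyrrolidin-1-yl gives a 3.4-fold higher number from compound 1 to compound 3 (0.54 log units; beyond the scatter). Nothing available here explains either step.

From the compounds shown here alone, whether fluoro or methoxy on the same carbon would give a step like that of chloro remains open. So does whether chloro would give a similar step with pyrrolidin-1-yl on the chain.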